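The compounds below may be only part of what the source reports. "The series", "measured", "known", "first", "only" and "open" are said of these compounds alone.

Measured compounds:
- compound 1, `CCCCc1cn(-c2ccc(NC(=O)Nc3cc(CCC(C)=O)ccc3C)cc2)nn1`: 2490 nM
- compound 2, `CCCCc1cn(-c2ccc(NC(=O)Nc3cc(O[C@H]4O[C@@H](CO)[C@H](O)[C@@H]4O)ccc3C)cc2)nn1`: "not active" (no number reported)

Compound 2 stands apart from compound 1 in that it carries no number at all: in an assay on isolated protein for inhibition of ATP-dependent RNA helicase DDX3X (Homo sapiens), read by FRET, with stated times of 30 s and 40 min (on this read-out lower numbers stand for stronger inhibition and higher numbers for weaker inhibition), compound 2 is reported as "not active" (no number reported), whereas compound 1 gives 2490 nM. Going by the values given here, with no number for compound 2, no step between the two can be drawn; what the pair shows is only that compound 1 inhibits measurably and compound 2 does not.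

Compound 3, `CCCCc1cn(-c2ccc(NC(=O)Nc3cc(OCOC)ccc3C)cc2)nn1`, differs from compound 2 in one place: methoxymethyl in place of 3,4-dihydroxy-5-(hydroxymethyl)oxolan-2-yl on an oxygen on an aromatic ring. The shared core of compound 2 and compound 3 is otherwise kept. Since compound 2 has no number, the size of the step to compound 3 in this assay cannot be given as a ratio; the expectation is only one of direction, from no reported inhibition toward a measurable but weak value, of the order that compound 1 shows with 2490 nM. Compound 3 is therefore expected to give about 5000 nM in this assay, within a range from 1500 nM to 30000 nM, with a real chance that again only a limit is reported.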

Compound 3, half-maximal inhibitory concentration: 820 nM
Estimate against measurement, compound 3: 6.1-fold (0.79 log units) above, outside the stated range (below it).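

Methoxymethoxy in place of 2-acetylethyl on an aromatic carbon gives a 3.0-fold lower number from compound 1 to compound 3 (0.48 log units; beyond the scatter) in this assay, so this position can carry a group linked through oxygen and still show measurable inhibition. Compound 2 has that same oxygen on the aromatic ring and yet has no reported number, whereas compound 3 gives 820 nM; the oxygen link alone therefore does not go with the loss of inhibition, although the step between these two cannot be read as a size. Nothing measured here accounts for either result.

The compounds shown leave open whether a plain methyl or a longer chain on that oxygen, or such a chain ending in an amine or a carboxylic acid, would give a lower or a higher number than compound 3. They also do not separate the two parts of the change from compound 2 to compound 3, the loss of the five-membered ring and the loss of its hydroxyl groups, since the 3,4-dihydroxy-5-(hydroxymethyl)oxolan-2-yl group and methoxymethyl differ in both at once.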